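Removing the drawn configuration: compound 3 to compound 4

The source may report more compounds than this note shows. Statements on the series, on what has been measured and on what is new or still open speak of the compounds shown alone.

Compound 1 `COc1ccc(F)cc1N1C(=O)CSC1c1cccc(C(=O)NCCCCn2cccn2)c1`: 97.3 nM
Compound 2 `COc1ccccc1N1C(=O)CSC1c1cccc(C(=O)NCCCCn2cccn2)c1`: 91.7 nM
Compound 3 `Cc1ccnc(N2C(=O)CS[C@H]2c2cccc(C(=O)NCCCCn3cccn3)c2)c1`: > 10000 nM, a limit

In a functional assay on HOS-TE85 cells (Homo sapiens) for inhibition, read by CCK-8 assay, with a stated time of 72 h (on this read-out lower numbers stand for stronger inhibition and higher numbers for weaker inhibition), compound 3 stands only at a limit, > 10000 nM, which is the limit of > 10000 nM in this assay, at which 1 of the 3 values shown sits. Compound 4 `Cc1ccnc(N2C(=O)CSC2c2cccc(C(=O)NCCCCn3cccn3)c2)c1` differs from it in that (the two compounds have the same atoms and bonds; at least one stereo element is drawn with a configuration in one of them and without one in the other: 1 of 1 stereo elements differ; a stereocentre at a saturated ring carbon is drawn S in compound 3 and without a configuration in compound 4). Among the measured compounds shown here, the single measured step, a 1.1-fold lower number from compound 1 to compound 2 (0.03 log units; within the scatter), concerns hydrogen in place of fluoro on an aromatic carbon and so does not bear on a stereo element; no measured step speaks to this change. In this assay compound 1 gives 97.3 nM and compound 2 gives 91.7 nM, both drawn without a configuration. With compound 3 at a limit, the size of the step cannot be read from the data. Compound 4 is expected at 300 nM, between 80 nM and 10000 nM. The expected step is an at least 33-fold lower number from compound 3 to compound 4 (1.52 log units; beyond the scatter).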

Compound 4, half-maximal inhibitory concentration: 19.6 nM
Compound 4: the middle estimate sits 15-fold (1.18 log units) above what was measured; measured number below the stated range.
By their numbers in this assay, from the lowest: compound 4; then compounds 2 and 1 (each within the scatter of the next). At a limit, above all of these: compound 3.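

In this assay compound 3 gives > 10000 nM as a limit. At the saturated ring carbon the change brings an at least 510-fold lower number from compound 3 to compound 4 (2.70 log units; beyond the scatter) and the sole difference is this: the fact that one of compounds 3 and 4 is drawn with a defined configuration and the other without, at the place where they differ. With 4-methylpyridin-2-yl on the amide-type nitrogen in a ring, the comparison with the methoxyphenyl compounds shows a 4.7-fold lower number from compound 2 to compound 4 (0.67 log units; beyond the scatter) and a 5.0-fold lower number from compound 1 to compound 4 (0.70 log units; beyond the scatter), both modest.

The compounds shown leave open how the activity of compound 4 divides between the S and R configurations at this carbon. They also leave open whether a 4-ethylpyridin-2-yl group would serve on that nitrogen.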